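From formyl to acetyl on a shared core

A few compounds are considered here, and "the series" means these few. Any claim that something is new, unique, unknown or untested is made for them only; others in the source may bear on it.

Three compounds with a shared core differ only in what sits on one carbonyl carbon. In a functional assay on NCI-H441 cells (Homo sapiens) for antiproliferative activity, with a stated time of 24 h (on this read-out lower numbers stand for stronger inhibition and higher numbers for weaker inhibition), compound 1 (`O=C(O)COCC(=O)N1C/C(=C\c2ccccc2F)C(=O)/C(=C/c2ccccc2F)C1`) gives 310000 nM, compound 2 (`O=C1/C(=C/c2ccccc2F)CN(C(=O)c2ccccc2C(=O)O)C/C1=C\c1ccccc1F`) gives 56000 nM and compound 3 (`O=CN1C/C(=C\c2ccccc2F)C(=O)/C(=C/c2ccccc2F)C1`) gives 49000 nM. Compound 3 is therefore level with compound 2 within the scatter, and both have clearly lower numbers than compound 1.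

Compound 4 (`CC(=O)N1C/C(=C\c2ccccc2F)C(=O)/C(=C/c2ccccc2F)C1`) has methyl in place of hydrogen on a carbonyl carbon, which turns formyl into acetyl: methyl in place of hydrogen on a carbonyl carbon. Among the measured compounds shown here, no measured compound carries this methyl, so the evidence is indirect. Two measured steps are modest but beyond the scatter, a 5.5-fold lower number from compound 1 to compound 2 (0.74 log units; beyond the scatter) and a 6.3-fold lower number from compound 1 to compound 3 (0.80 log units; beyond the scatter), and both start from the (carboxymethoxy)methyl group of compound 1. The step closest to the case at hand also ends on hydrogen: replacing 2-carboxyphenyl gives a 1.1-fold lower number from compound 2 to compound 3 (0.06 log units; within the scatter), which is within the scatter.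

Since the new group is small, no step beyond the scatter is expected in this assay, and neither direction is favoured. The estimated step is a 1.0-fold higher number from compound 3 to compound 4 (0.01 log units; within the scatter). Compound 4 is expected at 50000 nM, with an estimated range from 17000 nM to 150000 nM.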

Compound 4, half-maximal inhibitory concentration: 54000 nM
Estimate against measurement, compound 4: 1.1-fold (0.03 log units) below, and the stated range covers the measured number.
By their numbers in this assay, from the lowest: compounds 3, 4 and 2 (each within the scatter of the next); then compound 1.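

In this assay, putting methyl on the carbonyl carbon in place of hydrogen gives a 1.1-fold higher number from compound 3 to compound 4 (0.04 log units; within the scatter), so this one-carbon addition, which turns formyl into acetyl, produces no readable shift at this position. Methyl also reads level with a much larger group that holds a ring and a carboxylic acid, a 1.0-fold lower number from compound 2 to compound 4 (0.02 log units; within the scatter), so hydrogen, methyl and 2-carboxyphenyl on this carbonyl carbon cannot be told apart here. The acetyl group of compound 4 also offers a closer comparison with compound 1 than hydrogen did, since the two differ only by the carboxymethoxy on the saturated chain carbon, and that single difference gives a 5.7-fold lower number from compound 1 to compound 4 (0.76 log units; beyond the scatter), the same modest gap that separates compound 1 from the other two compounds.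

Nothing measured here explains why these groups read as they do. Still open, on these data alone, is whether a longer chain such as ethyl, an amine such as aminomethyl, or a shorter acid such as carboxymethyl on this carbonyl carbon would stay level with compound 4 or move towards compound 1.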